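Shortening a Chlorinated Chain on Two Related Compounds

A few compounds are considered here, and "the series" means these few. Any claim that something is new, unique, unknown or untested is made for them only; others in the source may bear on it.

Measured in a functional assay on MCF7 cells (Homo sapiens) for cytotoxicity, read by sulforhodamine B assay, with a stated time of 48 h; a lower number here means a stronger inhibitor, a higher number a weaker inhibitor:
- compound 1 `Cc1ccccc1NS(=O)(=O)c1cccc(NC(=O)NCCCCl)c1` gives 52000 nM
- compound 2 `Cc1ccccc1NS(=O)(=O)c1ccc(NC(=O)NCCCCl)cc1` gives only a limit, > 200000 nM
- compound 3 `CCNC(=O)Nc1cccc(S(=O)(=O)Nc2ccccc2C)c1` gives 108000 nM

Compound 1 and compound 2 are built from the same atoms joined differently; how their cores differ is not broken down here. Compound 3 arises from compound 1 by hydrogen in place of chloromethyl on a saturated chain carbon, two bonds along the chain from an amide-type nitrogen, and this step weakened inhibition: a 2.1-fold higher number from compound 1 to compound 3 (0.32 log units; beyond the scatter). Compound 4 `CCNC(=O)Nc1ccc(S(=O)(=O)Nc2ccccc2C)cc1` arises from compound 2 by the same change, (hydrogen in place of chloromethyl on a saturated chain carbon, two bonds along the chain from an amide-type nitrogen), at a place described in identical words.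

Compound 2 already sits at the limit of > 200000 nM in this assay, at which 1 of the 3 values shown sits. The step from compound 2 to compound 4 is expected to be a step that the limit leaves unreadable from compound 2 to compound 4, resting on a 2.1-fold higher number from compound 1 to compound 3 (0.32 log units; beyond the scatter). Compound 4 is therefore estimated at 400000 nM, between 150000 nM and 1200000 nM, and it is expected to be reported again only as a limit rather than a number.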

Compound 4, half-maximal inhibitory concentration: > 200000 nM
Compound 4 was reported as a limit (the forecaster's own chance of this, stated with the estimate: 85%); the middle value is on the limit's open side.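

Compound 2 and compound 4 are both reported only as limits, so no step can be read between them: the limit of > 200000 nM in this assay, at which 2 of the 4 values shown sit.

On these data alone, whether replacing 3-chloropropyl with ethyl changes inhibition on the core of compound 2 stays open.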